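The source may report more compounds than this note shows. Statements on the series, on what has been measured and on what is new or still open speak of the compounds shown alone.

Measured so far:
compound 1 `O=C(O)CCc1ccc(C#CC2CCCC2)cc1` — 94%
compound 2 `C/C=C\C#Cc1ccc(CCC(=O)O)c(F)c1` — 91%
compound 3 `O=C(O)CCc1ccc(C#CCc2ccccc2)cc1` — 103%

In a functional assay on 1321-N1 cells for agonist activity at Free fatty acid receptor 1 (Homo sapiens), read by calcium flux, with a stated time of 0.4 s (a higher number here means a larger maximal response, a lower number a smaller maximal response), compound 3 gives 103%, the highest of the three numbers. Compound 1 lies within the scatter of it, so no order between the two is claimed; compound 2 lies beyond the scatter, lower.

Compound 4 `O=C(O)CCc1ccc(C#CCCc2ccccc2)cc1` differs from compound 3 by benzyl in place of phenyl on a saturated chain carbon bound to a triple-bonded carbon. Among the compounds with values here, no pair of measured compounds shares this change, so the step is not anchored by a measured one. All three measured compounds reach a near-full maximal response, and compound 4 keeps the shared core and the acid chain of compound 3. The step of a number 6 percentage points lower from compound 3 to compound 4 (within the scatter) is therefore expected to stay within the scatter, in no particular direction. Compound 4 is estimated at 97%, in the range 80% to 110%.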

Compound 4, largest response reached (reported as efficacy), in percent of the reference or control that the assay uses: 128%
Beside the measured number, compound 4's estimate is 31 percentage points below it; measured number above the stated range.
By their numbers in this assay, from the lowest: compounds 2, 1 and 3 (each within the scatter of the next, the first and the last beyond it); then compound 4.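

In this assay, benzyl in place of phenyl on a saturated chain carbon bound to a triple-bonded carbon gives a number 25 percentage points higher from compound 3 to compound 4 (beyond the scatter) as a single-place change. Within the data shown here, the earlier compounds offered no such pair, so this is the first sign that the maximal response is sensitive to the group at this position. Nothing at hand accounts for the step.

Going by these compounds, whether a longer chain ending in phenyl carries the response further remains open, as does whether an ether oxygen or an amine in that chain preserves it.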